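Replacing the piperidin-1-yl group in compound 2

The source may hold more compounds than are shown below. What is called first, only, known or untested is meant among the compounds shown, and "the series" means these compounds.

Measured in an ADME assay on microsomes from liver (Mus musculus) for metabolic stability, read by LC-MS, using NADPH, with stated times of 10 min and 30 min, tested at 1 uM; on this read-out higher numbers stand for fast clearance and lower numbers for slow clearance:
- compound 1 `COC(=O)C1=C(C)NC(c2nccs2)=NC1(C)c1ccc(F)c(F)c1`: 83 mL/min/kg
- compound 2 `COC(=O)C1=C(CN2CCCCC2)NC(c2nccs2)=NC1(C)c1ccc(F)cc1`: 88 mL/min/kg

Clearance describes how quickly liver enzymes remove a compound, so these numbers show how long each compound may survive in this test. Compound 1 gives 83 mL/min/kg and compound 2 gives 88 mL/min/kg. These values lie within the usual scatter of repeated measurements, so the two compounds cannot be told apart here. They also differ in more than one place, so neither offers a clean single-change comparison.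

The next compound is compound 3 `COC(=O)C1=C(CN2CC3CC2CO3)NC(c2nccs2)=NC1(C)c1ccc(F)cc1`. It keeps the shared core of compound 2, but the piperidin-1-yl group gives way to a bridged group with no common name: a group of 7 heavy atoms (5 carbon, 1 nitrogen, 1 oxygen; 2 five-membered non-aromatic rings with 1 hetero atom each) in place of a group of 6 heavy atoms (5 carbon, 1 nitrogen; one six-membered non-aromatic ring with 1 hetero atom), on a saturated chain carbon bound to a double-bonded ring carbon. The change sits on a saturated chain carbon bound to a double-bonded ring carbon.

For the measured compounds named here, no measured pair shows the effect of this change, so any forecast is uncertain and its range must be wide. A modest fall in clearance is expected, and the expected 1.4-fold lower number from compound 2 to compound 3 (0.15 log units; within the scatter) may not go beyond the scatter. Compound 3 is estimated at 62 mL/min/kg, with an expected range of 32 mL/min/kg to 95 mL/min/kg.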

Compound 3, clearance: 84 mL/min/kg
The estimate for compound 3 lay 1.4-fold (0.13 log units) below the measured number; low and high end bracket the measured number.
By their numbers in this assay, from the lowest: compounds 1, 3 and 2 (each within the scatter of the next).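

In this assay the bridged group on a saturated chain carbon bound to a double-bonded ring carbon takes the place of the piperidin-1-yl group and gives a 1.0-fold lower number from compound 2 to compound 3 (0.02 log units; within the scatter), so the two compounds cannot be told apart. For the compounds shown here, this is the first comparison in the set in which only one place differs, and it shows that this exchange of one saturated amine ring system for another, with 2 hydrogen-bond acceptors in place of 1 and 2 five-membered rings in place of one six-membered ring, leaves the clearance reading unchanged within the scatter of repeated measurements. Nothing else measured on these compounds bears on this result.

A single pair cannot show whether this position is insensitive in general, and the compounds shown leave open whether an open-chain amine such as dimethylamino, or a carboxylic acid on the same chain carbon, would shift the clearance beyond the scatter. They also leave open whether a change elsewhere on the shared core, such as replacing the methyl ester with an amide, would do so.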